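The source may report more compounds than this note shows. Statements on the series, on what has been measured and on what is new or still open speak of the compounds shown alone.

Measured compounds:
compound 1 `COc1ccc(C(=O)N/N=C/c2cc(I)cc(I)c2O)cc1`, 45200 nM
compound 2 `CC(C)(C)c1ccc(C(=O)N/N=C/c2cc(I)cc(I)c2O)cc1`, 41600 nM
compound 3 `COc1ccc(C(=O)NNC(=O)c2cc(I)cc(I)c2O)cc1`, 132000 nM

All three values come from a functional assay on HepG2 cells (Homo sapiens) for cytotoxicity, with a stated time of 24 h; on this read-out lower numbers stand for stronger inhibition and higher numbers for weaker inhibition. Compound 1 and compound 2 share one core and differ only at one aromatic carbon: tert-butyl in place of methoxy on an aromatic carbon. The measured step for that change is a 1.1-fold lower number from compound 1 to compound 2 (0.04 log units; within the scatter), so the two values are not distinguished here. Compound 3 carries a different core; in this assay compound 3 gives 132000 nM, the highest of the three numbers, beyond the scatter from compound 1 and compound 2. How the two cores differ is not broken down here.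

Compound 4 `CC(C)(C)c1ccc(C(=O)NNC(=O)c2cc(I)cc(I)c2O)cc1` is not yet measured. It stands to compound 3 as compound 2 stands to compound 1: tert-butyl in place of methoxy on an aromatic carbon. The place lines of the two changes agree word for word, so the change is the same in both pairs. Because the step of a 1.1-fold lower number from compound 1 to compound 2 (0.04 log units; within the scatter) stayed within the scatter, the expected step from compound 3 to compound 4 is likewise small, a 1.1-fold lower number from compound 3 to compound 4 (0.02 log units; within the scatter). The estimate for compound 4 in this assay is 125000 nM, expected between 60000 nM and 260000 nM.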

Compound 4, half-maximal inhibitory concentration: 87300 nM
The estimate for compound 4 lay 1.4-fold (0.16 log units) above the measured number, and the stated range covers the measured number.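

In this assay, tert-butyl in place of methoxy on an aromatic carbon gives a 1.5-fold lower number from compound 3 to compound 4 (0.18 log units; within the scatter), so the step on the core of compound 3 also stays within the scatter. Set beside the step on the core of compound 1, this step is not distinguished from it: the same change on two cores in this assay, a 1.1-fold lower number (0.04 log units; within the scatter) from compound 1 to compound 2 and a 1.5-fold lower number (0.18 log units; within the scatter) from compound 3 to compound 4, 1.4-fold (0.14 log units) apart, within the scatter of two such steps. For these two cores, the change therefore carries over with no measurable difference in this read-out, but the finding rests on two pairs, one exchange of groups and one cell assay, and it does not show how the change would behave on any other core.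

The compounds shown leave open how either core would read in this assay with an amine, a carboxylic acid or a longer alkyl chain in the place held by methoxy and tert-butyl. Also open, going by these compounds, is how either core would read with bromine in place of the iodine atoms.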